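A few compounds are considered here, and "the series" means these few. Any claim that something is new, unique, unknown or untested is made for them only; others in the source may bear on it.

Values in an ADME assay on L02 cells (Homo sapiens) for cytotoxicity, read by MTT assay, with a stated time of 24 h; a lower number here means a stronger inhibitor, a higher number a weaker inhibitor:
- compound 1 `O=C1/C(=C/c2cccnc2)CN(S(=O)(=O)c2ccc(Br)cc2)C/C1=C\c1ccccc1F` gives 14600 nM
- compound 2 `O=C1/C(=C/c2ccncc2)CN(S(=O)(=O)c2ccc([N+](=O)[O-])cc2)C/C1=C\c1ccccc1F` gives 18400 nM
- compound 3 `O=C1/C(=C/c2ccncc2)CN(S(=O)(=O)c2ccc(Cl)cc2)C/C1=C\c1ccccc1F` gives 15000 nM

Compound 3 lies within the scatter of both compound 1 and compound 2, so the three values do not separate in this assay. The next step leads to compound 4 `O=C1/C(=C/c2ccncc2)CN(S(=O)(=O)c2ccc(Br)cc2)C/C1=C\c1ccccc1F`: bromo in place of chloro on an aromatic carbon, para to a large group. Among the measured compounds shown here, the one measured step at this place, a 1.2-fold lower number from compound 2 to compound 3 (0.09 log units; within the scatter), stayed within the scatter. Compound 1, which also carries (4-bromophenyl)sulfonyl, gives 14600 nM. No change beyond the scatter is expected in this assay, with an estimated no change at the digits printed from compound 3 to compound 4 (within the scatter). For compound 4 the expected value is 15000 nM, with an estimated range of 10000 nM to 22000 nM.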

Compound 4, half-maximal inhibitory concentration: 19400 nM
Compound 4: middle estimate off by 1.3-fold (0.11 log units), on the low side; the range from low to high includes it.
By their numbers in this assay, from the lowest: compounds 1, 3, 2 and 4 (each within the scatter of the next).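

In this assay, the aromatic carbon para to a large group tolerates bromo in place of chloro (a 1.3-fold higher number from compound 3 to compound 4 (0.11 log units; within the scatter)) and bromo in place of nitro (a 1.1-fold higher number from compound 2 to compound 4 (0.02 log units; within the scatter)), so these three substituents do not separate. The pair at the second place, pyridin-4-yl in place of pyridin-3-yl (a 1.3-fold higher number from compound 1 to compound 4 (0.12 log units; within the scatter)), does not separate either. No supporting data bear on these results.

Open, on these data alone, is whether an amine or a carboxylic acid on this aromatic carbon would move the number beyond the scatter in this assay.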